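Aryl swap on the enone of the shared core

A few compounds are considered here, and "the series" means these few. Any claim that something is new, unique, unknown or untested is made for them only; others in the source may bear on it.

Measured so far:
compound 1, `COc1ccc(/C=C/C(=O)c2ccc(Nc3cc(C)nc4nc(SCc5nc6ccccc6[nH]5)nn34)cc2)cc1`, 170 nM
compound 2, `Cc1cc(Nc2ccc(C(=O)/C=C/c3ccc4ccccc4c3)cc2)n2nc(SCC(=O)c3ccccc3)nc2n1`, 190 nM

In a functional assay on SW-620 cells (Homo sapiens) for cytotoxicity, read by MTT assay, with stated times of 4 h and 72 h, tested at 2 uM (on this read-out lower numbers stand for stronger inhibition and higher numbers for weaker inhibition), compound 1 gives 170 nM, and compound 2 gives 190 nM; the two numbers lie within the usual scatter of each other, so neither stands apart. Compound 3, `Cc1cc(Nc2ccc(C(=O)/C=C/c3cccc(F)c3)cc2)n2nc(SCc3nc4ccccc4[nH]3)nc2n1`, differs from compound 1 by 3-fluorophenyl in place of 4-methoxyphenyl on a double-bonded chain carbon bound to a double-bonded chain carbon. Among the compounds with values here, no measured pair shows this change, so the data give no direction for it. A step from compound 1 to compound 3 of a 1.5-fold higher number from compound 1 to compound 3 (0.17 log units; within the scatter) is expected, not beyond the scatter. For compound 3 the estimate is 250 nM, within 100 nM to 600 nM.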

Compound 3, half-maximal inhibitory concentration: 590 nM
Estimate against measurement, compound 3: 2.4-fold (0.37 log units) below; measured number inside the range.
By their numbers in this assay, from the lowest: compounds 1 and 2 (each within the scatter of the next); then compound 3.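

Within the data shown here, on the double-bonded chain carbon bound to a double-bonded chain carbon, the aryl group matters: in this assay, 3-fluorophenyl in place of 4-methoxyphenyl gives a 3.5-fold higher number from compound 1 to compound 3 (0.54 log units; beyond the scatter), the only readable step so far. This single pair changes both the ring substituent and its ring position, so it cannot assign the step to either alone. Nothing available explains the step.

Still open, as far as these compounds go, is whether 3-methoxyphenyl or 4-fluorophenyl would separate substituent from ring position. From the compounds shown here alone, how an unsubstituted phenyl or a 4-aminophenyl would read at this position is also open.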